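The source may report more compounds than this note shows. Statements on the series, on what has been measured and on what is new or still open speak of the compounds shown alone.

Measured so far in an ADME assay on HEL cells (Homo sapiens) for cytotoxicity; on this read-out higher numbers stand for lower toxicity in this test and lower numbers for higher toxicity in this test:

- compound 1, `O=C(COc1cccc2ccccc12)N/N=C/c1ccc(Cl)cc1`: 100 ug/mL
- compound 2, `C/C(=N\NC(=O)COc1cccc2ccccc12)c1ccccc1Br`: 16.2 ug/mL
- compound 3, `COc1cc(/C=N/NC(=O)COc2cccc3ccccc23)cc(OC)c1O`: 52.8 ug/mL

Compound 1 gives the highest of the three numbers in this assay, so among these compounds it shows the least toxicity. Compound 3 sits close to it: the gap between the two values lies within the usual scatter, so the two cannot be ranked against each other. Compound 2 is the odd one out, with a clearly lower number than compound 1 that lies beyond the scatter, which points to a more toxic compound.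

Compound 4, `O=C(COc1cccc2ccccc12)N/N=C/c1cccc(Br)c1`, has not yet been tested in this assay. It keeps the shared core of compound 1 and differs in one place: 3-bromophenyl in place of 4-chlorophenyl on a carbon with a double bond to nitrogen. The change swaps one halogen-bearing ring for another of the same size. Among the measured compounds shown here, with no measured pair of this kind to lean on, the expectation for compound 4 is a step of a 1.3-fold lower number from compound 1 to compound 4 (0.10 log units; within the scatter) from compound 1, that is, no shift beyond the scatter. Compound 4 is therefore estimated at 80 ug/mL, in a range from 40 ug/mL to 100 ug/mL.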

Compound 4, half-maximal cytotoxic concentration: 48.6 ug/mL
Compound 4: the middle estimate sits 1.6-fold (0.22 log units) above what was measured; measured number inside the range.
By their numbers in this assay, from the lowest: compound 2; then compounds 4, 3 and 1 (each within the scatter of the next, the first and the last beyond it).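

In this assay, among the compounds shown here, this is the first pair that differs in one place, and it gives a 2.1-fold lower number from compound 1 to compound 4 (0.31 log units; beyond the scatter), a modest step that nonetheless lies beyond the scatter. It shows that the number can respond to a swap at this carbon even when the two rings match in size and in their counts of hydrogen-bond donors and acceptors, and neither carries a net charge. Going from 4-chlorophenyl to 3-bromophenyl alters the halogen and its ring position together, and nothing measured here separates those two changes or explains the step.

The compounds shown leave open how 3-chlorophenyl and 4-bromophenyl would read at this place, which would pull the halogen and its position apart. They also leave open whether a halogen is needed at all, a question that a ring carrying an amine or a carboxylic acid instead could address.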